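Replacing the phenylethenyl arm with a chlorophenyl arm

The compounds below may be only part of what the source reports. "The series", "measured", "known", "first", "only" and "open" are said of these compounds alone.

Measured so far:
compound 1, `O=C1N=C(C2C(=O)c3ccccc3C2=O)CC(c2cccc([N+](=O)[O-])c2)N1`, 27%
compound 2, `O=C1N=C(C2C(=O)c3ccccc3C2=O)CC(/C=C/c2ccccc2)N1`, 17%

Among the compounds with values here, in a functional assay on the whole organism for inhibition, with Rattus norvegicus as the target, read by paw edema, with stated times of 30 min and 1 h, at a dose of 10 mg/kg by the oral route (a higher number here means more inhibition at the dose given (going by the name of the read-out), a lower number less inhibition), compound 2 gives 17%, and its only neighbour is compound 1, separated by a number 10 percentage points lower from compound 1 to compound 2 (within the scatter). Compound 3, `O=C1N=C(C2C(=O)c3ccccc3C2=O)CC(c2ccc(Cl)cc2)N1`, differs from compound 2 by 4-chlorophenyl in place of 2-phenylethenyl on a saturated ring carbon. Within the data shown here, the single measured step concerns a different exchange at that carbon and stays within the scatter, so it gives no direction for this one. Among the measured compounds shown here, compound 3 is therefore expected near the two known numbers, with an estimated step of a number 7 percentage points higher from compound 2 to compound 3 (within the scatter) in this assay. The estimated value of compound 3 is 24%, between 10% and 40%.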

Compound 3, a percentage reported as inhibition, in the whole organism at one dose (the size of the read-out at that dose, not a potency): 15%
Compound 3: middle estimate off by 9 percentage points, on the high side; the range from low to high includes it.
By their numbers in this assay, from the lowest: compounds 3, 2 and 1 (each within the scatter of the next, the first and the last beyond it).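

In this assay, the exchange of 2-phenylethenyl for 4-chlorophenyl on the saturated ring carbon leaves the two arms inseparable (a number 2 percentage points lower from compound 2 to compound 3 (within the scatter)). Within the data shown here, the exchange of 3-nitrophenyl for 4-chlorophenyl gives the only step at this position that lies beyond the scatter, and it is a modest one (a number 12 percentage points lower from compound 1 to compound 3 (beyond the scatter)). The compounds shown leave open how this read-out would respond to an amine or a carboxylic acid on the aromatic ring, or to a longer chain at this carbon. Nothing measured here accounts for the difference between these two arms.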